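Carboxy to Methoxycarbonyl: the Expected Cytotoxicity of Compound 4

The source may hold more compounds than are shown below. What is called first, only, known or untested is meant among the compounds shown, and "the series" means these compounds.

Of the compounds shown here, three sharing one core have been tested in an ADME assay on BJ cells (Homo sapiens) for cytotoxicity, with a stated time of 72 h; a higher number here means that more compound is needed for the effect, a lower number that less compound is needed. Compound 1, `Cc1cc(NC(=O)Nc2ccc([N+](=O)[O-])c(C(F)(F)F)c2)c2ccccc2n1`, reached only the limit of the assay, > 25000 nM. Compound 3, `Cc1cc(NC(=O)Nc2cccc(C(N)=O)c2)c2ccccc2n1`, likewise gave a limit rather than a number, > 25000 nM. Compound 2, `Cc1cc(NC(=O)Nc2ccc(C(=O)O)cc2)c2ccccc2n1`, stands at the same point: in this assay compound 2 shows a limit, > 25000 nM, and no number. So for compound 2 nothing more is known than the limit of > 25000 nM in this assay, at which 3 of the 3 values shown sit, which is all that the shown results contain.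

Compound 4, `COC(=O)c1ccc(NC(=O)Nc2cc(C)nc3ccccc23)cc1`, has not yet been measured. It differs from compound 2 by methyl in place of hydrogen on an oxygen next to a carbonyl group; seen one bond further out, the change reads carboxy to methoxycarbonyl.

Among the measured compounds shown here, no step between two measured compounds is available to calibrate this change. Given that every value shown sits at the limit, the step from compound 2 to compound 4 in this assay is expected to be none beyond the scatter, with no direction to assign, so that a step that the limit leaves unreadable from compound 2 to compound 4 is the expected outcome. Compound 4 is therefore estimated at 30000 nM in this assay, in an expected range from 12000 nM to 90000 nM, most likely again reported only as a limit.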

Compound 4, half-maximal effective concentration: 21000 nM
Compound 4: the middle estimate sits 1.4-fold (0.15 log units) above what was measured, within the range that was stated.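

In this assay compound 4 gives a reading, 21000 nM, so the position on the oxygen next to a carbonyl group now yields a number rather than a limit of the assay. Among the compounds shown here, the change from carboxy to methoxycarbonyl can therefore be put as a step for the first time, though only as a floor: an at least 1.1-fold lower number from compound 2 to compound 4 (0.07 log units; that floor lies within the scatter). The other end of that step stays hidden, as compound 2 remains a limit and not a number: the limit of > 25000 nM in this assay, at which 3 of the 4 values shown sit.

The compounds shown do not tell how large the step truly is, and a floor of this size does not settle whether the methyl in place of hydrogen changes the read-out at all. They also leave open how an ethyl group or a longer chain on the same oxygen would read, or how an amine in place of the methoxy would read, with the rest of compound 4 held as it is.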